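A few compounds are considered here, and "the series" means these few. Any claim that something is new, unique, unknown or untested is made for them only; others in the source may bear on it.

Three compounds share one core and differ only in the aryl group attached to the carbonyl carbon. Compound 1 `COC(=O)c1cc(-c2cccc(NC(=O)c3ccc(/C=C/C(=O)c4cccc(F)c4)cc3)c2)on1` carries a 3-fluorophenyl there. In an ADME assay on Vero cells (Chlorocebus sabaeus) for cytotoxicity, read by MTT assay, with a stated time of 72 h (a lower number here means that less compound is tolerated, a higher number that more compound is tolerated), compound 1 gives only a limit, > 40 ug/mL. Compound 2 `COC(=O)c1cc(-c2cccc(NC(=O)c3ccc(/C=C/C(=O)c4cccc(C(F)(F)F)c4)cc3)c2)on1` carries a 3-(trifluoromethyl)phenyl, trifluoromethyl in place of fluoro on an aromatic carbon. In this assay compound 2 again gives only a limit, > 20 ug/mL. Compound 3 `COC(=O)c1cc(-c2cccc(NC(=O)c3ccc(/C=C/C(=O)c4ccccc4Br)cc3)c2)on1` carries a 2-bromophenyl. In this assay compound 3 gives a limit as well, > 40 ug/mL. Two of the three values sit at the limit of > 40 ug/mL in this assay, at which 2 of the 3 values shown sit. The remaining one sits at the limit of > 20 ug/mL in this assay, at which 1 of the 3 values shown sits. No number is known for any of the three, so compound 3 stands among values that are all limits. The step that the two limits leave unreadable from compound 1 to compound 2 cannot be sized, and the same holds for a step that the two limits leave unreadable from compound 1 to compound 3 and for a step that the two limits leave unreadable from compound 2 to compound 3.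

Compound 4 `COC(=O)c1cc(-c2cccc(NC(=O)c3ccc(/C=C/C(=O)c4ccc(C)c([N+](=O)[O-])c4)cc3)c2)on1` differs from compound 3 by 4-methyl-3-nitrophenyl in place of 2-bromophenyl on a carbonyl carbon. The measured steps touch the same place but give no readable size, so they offer no direction. Compound 4 is therefore expected to sit in the same region in this assay, around 50 ug/mL, with a range from 25 ug/mL to 100 ug/mL. The step that the limit leaves unreadable from compound 3 to compound 4 that this estimate means is expected to be none beyond the scatter.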

Compound 4, half-maximal cytotoxic concentration: > 80 ug/mL
Compound 4 was reported as a limit; the forecaster's own chance of this, stated with the estimate: 80%; middle value at least 1.6-fold (0.20 log units) from the limit.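

In this assay compound 4 also gives only a limit, > 80 ug/mL. With compound 1, compound 2 and compound 3 likewise known only as limits, none of the steps to compound 4 can be read. The compounds shown leave open where any of the four truly stands in this assay, and whether changing the aryl group on the carbonyl carbon shifts the value at all.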